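Benzothiazole-phenoxy ethers: three cytotoxicity values and one open slot

This account rests on a few compounds, and the source may have more. Where it says the series, first, only, none or still open, it means among the compounds named here.

Measured compounds in the series, with their values:
Compound 1 `FC(F)(F)C(F)(F)C(F)(F)C(F)(F)C(F)(F)C(F)(F)CCn1cc(COc2ccccc2-c2nc3ccccc3s2)nn1` gives 19800 nM in a functional assay on MCF7 cells (Homo sapiens) for cytotoxicity, read by MTT assay, with a stated time of 24 h; on this read-out higher numbers stand for weaker inhibition and lower numbers for stronger inhibition.
Compound 2 `Fc1ccc(-n2cc(COc3ccccc3-c3nc4ccccc4s3)nn2)cc1Cl` gives 27300 nM in this assay.
Compound 3 `FC(F)(F)Oc1ccc(-c2cc(COc3ccccc3-c3nc4ccccc4s3)on2)cc1` gives 26600 nM in this assay.

All three numbers fall close together. Compound 3 holds the second highest of the three; its nearest neighbour is compound 2, whose number lies within the scatter of it, and its furthest is compound 1, whose number is lower but also within the scatter. On the numbers shown there is therefore no ordering to speak of among the three compounds, and no step between compounds that differ in one place is available to calibrate what a single substituent swap does here.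

Compound 4 `Brc1ccc(-c2cc(COc3ccccc3-c3nc4ccccc4s3)on2)cc1` is the unmeasured member. It differs from compound 3 as follows: bromo in place of trifluoromethoxy on an aromatic carbon — bromo in place of trifluoromethoxy on an aromatic carbon, para to a large group, the shared core being untouched.

With three values that sit within the scatter of each other despite the variation at the outer end of the molecule, the expectation for this assay is a step from compound 3 to compound 4 of no more than the scatter, in no particular direction, a 1.1-fold lower number from compound 3 to compound 4 (0.03 log units; within the scatter). Compound 4 is therefore estimated at 25000 nM, with a range from 12000 nM to 50000 nM.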

Compound 4, half-maximal inhibitory concentration: 20000 nM
The estimate for compound 4 lay 1.3-fold (0.10 log units) above the measured number; measured number inside the range.
By their numbers in this assay, from the lowest: compounds 1, 4, 3 and 2 (each within the scatter of the next).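

In this assay, going by these compounds alone, the change from 4-(trifluoromethoxy)phenyl to 4-bromophenyl gives a 1.3-fold lower number from compound 3 to compound 4 (0.12 log units; within the scatter), the only step so far that isolates a single place. At this aromatic carbon, para to a large group, a group of 5 heavy atoms with 1 hydrogen-bond acceptor gives way to a single bromine atom with no hydrogen-bond acceptor, and the read-out stays within the scatter, so for this pair neither the size count nor the acceptor count registers in the numbers. No measurement on hand bears on why this step is so small.

What the compounds shown leave open is whether any group at this carbon can move the number beyond the scatter, as an amine, a carboxylic acid or a hydroxyl might or might not do, since every group seen here is free of hydrogen-bond donors and carries no net charge. From the compounds shown here alone, it also remains open whether the shared core itself, rather than the outer group, sets the level of these values, which calls for a compound changed in the core with the 4-bromophenyl group kept in place.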